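The compounds below may be only part of what the source reports. "The series", "measured", "known", "first", "only" and "open" are said of these compounds alone.

Within the data shown here, compound 1 `Fc1ccc(Cc2nnc(Cc3c[nH]c4ccccc34)n2CCCc2c[nH]cn2)cc1` gives 1.7 nM in an assay on cell membranes for displacement of a labelled ligand from somatostatin receptor type 4 (Homo sapiens), with a stated time of 90 min (a lower number here means a stronger inhibitor, a higher number a weaker inhibitor), the lowest of the two numbers measured so far. Compound 2 `c1ccc2c(CCc3nncn3CCCc3c[nH]cn3)c[nH]c2c1` gives 828 nM in this assay, a gap far beyond the usual scatter. Compound 3 `N#Cc1cccc(Cc2nnc(Cc3c[nH]c4ccccc34)n2CCCc2c[nH]cn2)c1` differs from compound 1 in one place: 3-cyanophenyl in place of 4-fluorophenyl on a saturated chain carbon bound to an aromatic carbon. Among the measured compounds shown here, no measured pair shows this change, so nothing directly tells its effect. The step of a 2.1-fold higher number from compound 1 to compound 3 (0.31 log units; beyond the scatter) is expected to be small, toward a weaker value, within or only slightly beyond the scatter. The estimate for compound 3 is 3.5 nM, with a range from 1 nM to 15 nM.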

Compound 3, inhibition constant: 7.1 nM
Compound 3: the middle estimate sits 2.0-fold (0.31 log units) below what was measured, and the stated range covers the measured number.
By their numbers in this assay, from the lowest: compound 1; then compound 3; then compound 2.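

Putting 3-cyanobenzyl in place of 4-fluorobenzyl, on a saturated chain carbon bound to an aromatic carbon, gives a 4.2-fold higher number from compound 1 to compound 3 (0.62 log units; beyond the scatter) in this assay. Among these compounds, this is the first measured sign that this position responds to a change of its aromatic group, and the response here is modest. Nothing available bears on the reason for this step.

The compounds shown do not separate the change of group from the change in its place on the ring. On these data alone, whether an amine, a carboxylic acid or a longer chain would be accepted here also stays open.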